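The source may report more compounds than this note shows. Statements on the series, on what has been measured and on what is new or still open speak of the compounds shown alone.

Compound 1 `Cc1cc(C)cc(S(=O)(=O)c2c(C(=O)NC3CC4(CCN(Cc5n[nH]c(=O)n5C)C4)C3)[nH]c3ccc(Cl)cc23)c1` in a toxicity assay on MT4 cells (Homo sapiens) for cytotoxicity, read by MTT assay, with a stated time of 7 days (a lower number here means that less compound is tolerated, a higher number that more compound is tolerated), gives > 214000 nM, which is a limit of the assay rather than a number, sitting at the limit of > 214000 nM in this assay, at which 1 of the 2 values shown sits. Compound 2 `Cc1cc(C)cc(S(=O)(=O)c2c(C(=O)NC3CC4(CCN(Cc5n[nH]c(=O)n5C)CC4)C3)[nH]c3ccc(Cl)cc23)c1` in this assay gives 178000 nM. Compound 3 `Cc1cc(C)cc(S(=O)(=O)c2c(C(=O)NC3CC4(CCN(S(C)(=O)=O)C4)C3)[nH]c3ccc(Cl)cc23)c1` carries a group of 4 heavy atoms (1 carbon, 2 oxygen, 1 sulfur; no ring) in place of a group of 8 heavy atoms (4 carbon, 3 nitrogen, 1 oxygen; one five-membered aromatic ring with 3 hetero atoms), on an amine nitrogen in a ring. Going by the values given here, no measured pair isolates this change, so the step from compound 1 to compound 3 in this assay is expected to stay within the scatter, with no set direction, both measured values lying near the upper edge of what this assay reports. For compound 3 the expected value in this assay is 190000 nM, between 95000 nM and 260000 nM. The expected step is an at least 1.1-fold lower number from compound 1 to compound 3 (0.05 log units; that floor lies within the scatter).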

Compound 3, half-maximal cytotoxic concentration: 205000 nM
Compound 3: middle estimate off by 1.1-fold (0.03 log units), on the low side; low and high end bracket the measured number.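

In this assay, methylsulfonyl on the amine nitrogen of the five-membered non-aromatic ring, in place of the group carrying the five-membered aromatic ring, gives an at least 1.0-fold lower number from compound 1 to compound 3 (0.01 log units; that floor lies within the scatter). This first exchange at this position shows that a group with no ring and no hydrogen-bond donor also leaves the value near the upper edge of the assay's reported range. The value of compound 1 is a limit, so the step has no set size: the limit of > 214000 nM in this assay, at which 1 of the 3 values shown sits.

Open, as far as these compounds go, is whether a benzyl or acetyl group on this nitrogen would give a step beyond the scatter in this assay.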